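The source may report more compounds than this note shows. Statements on the series, on what has been measured and on what is new or still open speak of the compounds shown alone.

Measured compounds:
compound 1 `CC(=O)OCCc1c(C)[nH]c(=O)[nH]c1=O` — > 100000 nM
compound 2 `CC(=O)OCCc1c(C)nc(Cl)nc1Cl` — > 100000 nM
compound 3 `COc1nc(C)c(CCO)c(OC)n1` — > 100000 nM

All three compounds were tested in a functional assay on HCT-116 cells (Homo sapiens) for antiproliferative activity, read by MTT assay, with a stated time of 24 h; a higher number here means a weaker inhibitor, a lower number a stronger inhibitor. For compound 1 the value > 100000 nM is a limit of the assay, not a number. For compound 2 the value > 100000 nM is likewise a limit. For compound 3 the value > 100000 nM is again a limit, so compound 3 stands only at the edge of what this assay can report, with no measured number of its own. The point of reference is the limit of > 100000 nM in this assay, at which 3 of the 3 values shown sit.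

Compound 4 `COc1nc(Cl)nc(C)c1CCO` has not been measured. The change from compound 3 is chloro in place of methoxy on an aromatic carbon. Among the compounds with values here, no step between two measured compounds is available to calibrate what such a change does here. Given that compound 2, which carries two chloro groups, also sits at a limit, and that compound 3 sits at a limit, the expectation is that compound 4 will show no movement beyond the scatter and will most likely again return only a limit. The expected step from compound 3 is a step that the limit leaves unreadable from compound 3 to compound 4. For compound 4 the estimate in this assay is 150000 nM, with a range from 40000 nM to 600000 nM.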

Compound 4, half-maximal inhibitory concentration: > 100000 nM
Compound 4 was reported as a limit; the forecaster's own chance of this, stated with the estimate: 85%; the middle value does not contradict the limit.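

Compound 3 and compound 4 both sit at a limit of this assay rather than at a number, so no step can be read for chloro in place of methoxy: the limit of > 100000 nM in this assay, at which 4 of the 4 values shown sit. The compounds shown leave open whether any change to the shared core would give a measurable value in this assay.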